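Furanyl swap on a cytotoxicity series: no readable step

The source may hold more compounds than are shown below. What is called first, only, known or untested is meant among the compounds shown, and "the series" means these compounds.

Compound 3 `Cc1nc(N)c2c(-c3ccoc3)cn([C@@H]3O[C@H](CO)[C@@H](O)[C@H]3O)c2n1` and compound 1 `Cc1nc(N)c2c(-c3ccco3)cn([C@@H]3O[C@H](CO)[C@@H](O)[C@H]3O)c2n1` share one core and differ only in the furanyl group. In an ADME assay on BJ cells (Homo sapiens), read by MTT assay, with a stated time of 72 h (a higher number here means a weaker inhibitor, a lower number a stronger inhibitor), compound 3 gives only a limit, > 100000 nM. Compound 1 gives the same kind of result in this assay, a limit of > 100000 nM. The change between them, (furan-2-yl in place of furan-3-yl on an aromatic carbon), thus produces a step that the two limits leave unreadable from compound 3 to compound 1, both results sitting at the limit of > 100000 nM in this assay, at which 3 of the 3 values shown sit.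

Compound 2 `COc1nc(N)nc2c1c(-c1ccoc1)cn2[C@@H]1O[C@H](CO)[C@@H](O)[C@H]1O` carries a second core; the difference between the two cores is not broken down here. In this assay compound 2 also gives only a limit, > 100000 nM.

Compound 4 `COc1nc(N)nc2c1c(-c1ccco1)cn2[C@@H]1O[C@H](CO)[C@@H](O)[C@H]1O` remains to be measured in this assay. It differs from compound 2 by furan-2-yl in place of furan-3-yl on an aromatic carbon, the same change that leads from compound 3 to compound 1, at a place described in identical words. Going by the values given here, since every value seen so far is a limit and the one matched step is unreadable, no direction can be drawn from the earlier pair. For compound 4 a step that the limit leaves unreadable from compound 2 to compound 4 is expected. This expectation rests on compound 2, whose result is the limit > 100000 nM. It rests also on a step that the two limits leave unreadable from compound 3 to compound 1 giving no sign of a shift. Compound 4 is therefore estimated at 150000 nM, within 60000 nM to 400000 nM, and is most likely to be reported again only as a limit.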

Compound 4, half-maximal inhibitory concentration: > 100000 nM
Compound 4 was reported as a limit; the forecaster's own chance of this, stated with the estimate: 88%; the middle value does not contradict the limit.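

Compound 2 and compound 4 are both reported only as limits in this assay, so no step can be read between them, and the same holds for compound 3 and compound 1: the limit of > 100000 nM in this assay, at which 4 of the 4 values shown sit.

The compounds shown leave open where any of the four truly lies beyond that limit, and whether the furanyl swap or the difference between the two cores shifts the read-out at all.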